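Trimming the Side Chain of a Weak Thiourea Inhibitor

The source may hold more compounds than are shown below. What is called first, only, known or untested is meant among the compounds shown, and "the series" means these compounds.

In a functional assay on MCF7 cells (Homo sapiens) for cytotoxicity, read by MTT assay (on this read-out lower numbers stand for stronger inhibition and higher numbers for weaker inhibition), compound 2 `CC(C)C[C@@H](NC(=S)Nc1cc(C(F)(F)F)cc(C(F)(F)F)c1)c1nc2ccccc2[nH]1` gives 91000 nM, the highest number among the three compounds measured, so it is the weakest of them. Compound 3 `CC(C)C[C@@H](NC(=S)NCc1ccccc1)c1nc2ccccc2[nH]1` gives 18200 nM and compound 1 `CC(C)[C@H](NC(=S)Nc1ccccc1)c1nc2ccccc2[nH]1` gives 9800 nM, and each of them sits more than the usual scatter away from compound 2. Compound 4 `C[C@@H](NC(=S)Nc1cc(C(F)(F)F)cc(C(F)(F)F)c1)c1nc2ccccc2[nH]1` keeps the thiourea and the two trifluoromethyl groups of compound 2 but carries hydrogen in place of isopropyl on a saturated chain carbon, two bonds along the chain from an amide-type nitrogen and an aromatic carbon. Going by the values given here, no pair of measured compounds shows this change on its own, so its direction is uncertain; a modest step, probably toward a lower number, is expected a 1.5-fold lower number from compound 2 to compound 4 (0.18 log units; within the scatter). Compound 4 is therefore expected to give 60000 nM in this assay, within 15000 nM to 200000 nM.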

Compound 4, half-maximal inhibitory concentration: 10300 nM
For compound 4 the middle estimate is 5.8-fold (0.77 log units) above the measured one, and the stated range ends above it.
By their numbers in this assay, from the lowest: compounds 1, 4 and 3 (each within the scatter of the next); then compound 2.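

Swapping isopropyl for hydrogen on the saturated chain carbon, which shortens isobutyl to methyl, gives an 8.8-fold lower number from compound 2 to compound 4 (0.95 log units; beyond the scatter) in this assay. Going by these compounds alone, this is the only change here seen on its own, and it shows that the side chain alone can shift the number beyond the scatter while the thiourea and both trifluoromethyl groups stay fixed. Nothing measured here explains this shift. Going by these compounds, whether an ethyl chain at this carbon would give a number between those of compound 2 and compound 4 stays open, as does the effect of an amine there.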